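The source may hold more compounds than are shown below. What is called first, only, known or untested is meant among the compounds shown, and "the series" means these compounds.

Measured in an ADME assay on HOS cells (Homo sapiens) for cytotoxicity, read by luminescence and ATP content, with a stated time of 48 h; a lower number here means that less compound is tolerated, a higher number that more compound is tolerated:
- compound 1 `COc1ccc2c(N)c(C(=O)NCc3ccc(F)cc3F)c(=O)n(O)c2n1`: 2200 nM
- compound 2 `O=C(NCc1ccc(F)cc1F)c1c(O)c2cc(CCCCCO)cnc2n(O)c1=O`: > 250000 nM (a limit)
- compound 3 `Nc1c(C(=O)NCc2ccc(F)cc2F)c(=O)n(O)c2ncc(CCCOCCO)cc12`: > 250000 nM (a limit)

Compound 3 gives only a limit (> 250000 nM) and not a number. It is one of the compounds at the limit of > 250000 nM in this assay, at which 2 of the 3 values shown sit, and so has no exact place on the scale. Among the measured compounds shown here, compound 1 is the only one with a true number (2200 nM).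

Compound 4 `Nc1c(C(=O)NCc2ccc(F)cc2F)c(=O)n(O)c2ncc(CCC(=O)NCCO)cc12` keeps the core of compound 3 and changes the chain. In it, (2-hydroxyethyl)carbamoyl takes the place of (2-hydroxyethoxy)methyl on a saturated chain carbon, two bonds along the chain from an aromatic carbon ((2-hydroxyethyl)carbamoyl in place of (2-hydroxyethoxy)methyl on a saturated chain carbon, two bonds along the chain from an aromatic carbon).

For the measured compounds named here, no two measured compounds differ in one place only, so no measured step can serve as a guide. Judging from compound 3 (> 250000 nM, again a limit), no step beyond the usual scatter is expected in this assay and no clear direction. As an estimate, the expected step runs an at least 1.2-fold lower number from compound 3 to compound 4 (0.09 log units; that floor lies within the scatter) and stays small. In this assay compound 4 is expected near 200000 nM (estimated range 60000 nM to 400000 nM).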

Compound 4, half-maximal cytotoxic concentration: > 250000 nM
Compound 4: only a limit was reported; the forecaster's own chance of this, stated with the estimate: 60%; at least 1.2-fold (0.09 log units) between middle value and limit.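

Compound 3 and compound 4 each give only a limit and not a number, so no step between them can be read: the limit of > 250000 nM in this assay, at which 3 of the 4 values shown sit.

The compounds shown leave open whether (2-hydroxyethyl)carbamoyl in place of (2-hydroxyethoxy)methyl changes how much compound the cells tolerate.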